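A few compounds are considered here, and "the series" means these few. Any claim that something is new, unique, unknown or untested is made for them only; others in the source may bear on it.

Working notes on the series.

Going by the values given here, compound 2 `CC(C)CNC(=O)NCCCOc1cccc(CN2CCCCC2)c1` stands at the lower end of the two numbers so far: in an assay on isolated protein for inhibition of histamine H2 receptor (Cavia porcellus) (a lower number here means tighter binding, a higher number weaker binding), compound 2 gives 170 nM. The other member, compound 1 `COc1ccc(N/C(S)=N/CCCOc2cccc(CN3CCCCC3)c2)cc1`, carries a thiourea and a 4-methoxyphenyl group in place of the urea and isobutyl of compound 2, so the two differ in more than one place and no single step can be read between them; in this assay compound 1 gives 4370 nM, a markedly higher number than that of compound 2.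

The next compound, compound 3 `O=C(NCCCOc1cccc(CN2CCCCC2)c1)Nc1ccc(C(F)(F)F)cc1`, keeps the urea and the shared core of compound 2 and changes one thing: 4-(trifluoromethyl)phenyl in place of isobutyl on an amide-type nitrogen. Among the compounds with values here, no measured pair isolates an alkyl-to-aryl swap on this nitrogen, so the expectation rests on the two numbers above alone. Within the data shown here, the only aryl-bearing member, compound 1, sits at 4370 nM, but its thiourea confounds the comparison. A moderate rise in the dissociation constant is expected, a 2.9-fold higher number from compound 2 to compound 3 (0.47 log units; beyond the scatter), likely beyond the scatter but well short of the gap to compound 1. Compound 3 is therefore estimated at 500 nM in this assay, with a plausible range from 120 nM to 2500 nM.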

Compound 3, dissociation constant: 1700 nM
Beside the measured number, compound 3's estimate is 3.4-fold (0.53 log units) below it; measured number inside the range.
By their numbers in this assay, from the lowest: compound 2; then compound 3; then compound 1.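

Going by these compounds alone, the swap of isobutyl for 4-(trifluoromethyl)phenyl on the amide-type nitrogen is the first single-place change that can be read: in this assay, it gives a 10-fold higher number from compound 2 to compound 3 (1.00 log units; beyond the scatter). With the urea and the shared core held constant, the group on this nitrogen clearly matters to the number, a point that compound 1 and compound 2 could not establish, since they differ in more than one place. No supporting measurement bears on what lies behind this step.

A single step cannot separate the arrival of the aromatic ring from that of the trifluoromethyl group, nor from the rise from 4 to 10 heavy atoms, so an unsubstituted phenyl or a cyclohexyl group on this nitrogen would be the informative comparison, as would a longer alkyl chain in place of isobutyl. From the compounds shown here alone, whether the thiourea of compound 1 or its 4-methoxyphenyl group weighs more also stays open, and a urea carrying 4-methoxyphenyl would connect compound 1 to this urea pair through a single change.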